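The compounds below may be only part of what the source reports. "The series", "measured", "known", "first", "only" and "open" are said of these compounds alone.

In a functional assay on HeLa cells (Homo sapiens) for cytotoxicity, in the presence of a further agent that is not named here (a higher number here means a weaker inhibitor, a lower number a stronger inhibitor), compound 1 (`Cc1cccc(-c2cc(-c3ccc(Cl)o3)cc(-c3ccsc3)n2)c1`) gives 20300 nM and compound 2 (`Cc1ccc(-c2cc(-c3ccoc3)cc(-c3ccsc3)n2)cc1`) gives 1470 nM as the lower of the two numbers, a gap beyond the scatter. Compound 3 (`Clc1ccc(-c2cc(-c3ccoc3)cc(-c3ccsc3)n2)cc1`) differs from compound 2 by chloro in place of methyl on an aromatic carbon, para to a large group (chloro in place of methyl on an aromatic carbon), that is, 4-methylphenyl to 4-chlorophenyl. Among the compounds with values here, no measured pair shows this change, so the data give no direction. The expected step is a 1.0-fold higher number from compound 2 to compound 3 (0.01 log units; within the scatter) and is estimated to stay within the scatter. Compound 3 is expected at 1500 nM with an estimated range (600 nM to 4000 nM).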

Compound 3, half-maximal inhibitory concentration: 4140 nM
Compound 3: the middle estimate sits 2.8-fold (0.44 log units) below what was measured; measured number outside the range, above it.
By their numbers in this assay, from the lowest: compound 2; then compound 3; then compound 1.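

In this assay, within the data shown here, the series now has its only single-place comparison, a 2.8-fold higher number from compound 2 to compound 3 (0.45 log units; beyond the scatter), for 4-methylphenyl to 4-chlorophenyl. This position, para to a large group, is therefore sensitive to the substituent, with methyl giving the lower number of the pair, though the step is modest. Nothing on hand accounts for the step.

Open, on these data alone, is whether an amine, a methoxy group or a carboxylic acid at this position would go below compound 2. Also open, as far as these compounds go, is whether the same change gives a step of the same direction with the other groups on the core.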